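Removing a Bromine from a Fluorinated Amide Pair

A few compounds are considered here, and "the series" means these few. Any claim that something is new, unique, unknown or untested is made for them only; others in the source may bear on it.

Of the compounds shown here, three sharing one core have been tested in a functional assay on MCF7 cells (Homo sapiens) for cytotoxicity, read by MTT assay, with a stated time of 72 h; on this read-out higher numbers stand for weaker inhibition and lower numbers for stronger inhibition. Compound 1 `O=C(Nc1ccc(Oc2ccnc3[nH]ccc23)cc1)c1nn(-c2ccc(Br)cc2)ccc1=O` gives 7890 nM in this assay. Compound 2 `O=C(Nc1ccc(Oc2ccnc3[nH]ccc23)cc1)c1nn(-c2ccccc2)ccc1=O` differs from compound 1 by hydrogen in place of bromo on an aromatic carbon. In this assay compound 2 gives 15600 nM. That change made a 2.0-fold higher number from compound 1 to compound 2 (0.30 log units; within the scatter). Compound 3 `O=C(Nc1ccc(Oc2ccnc3[nH]ccc23)c(F)c1)c1nn(-c2ccc(Br)cc2)ccc1=O` differs from compound 1 in its core by fluoro in place of hydrogen on an aromatic carbon. In this assay compound 3 gives 11600 nM. That change made a 1.5-fold higher number from compound 1 to compound 3 (0.17 log units; within the scatter). All three numbers lie close together, so none of them can be singled out as stronger or weaker than the others.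

Compound 4 `O=C(Nc1ccc(Oc2ccnc3[nH]ccc23)c(F)c1)c1nn(-c2ccccc2)ccc1=O` has not yet been measured. It differs from compound 3 by hydrogen in place of bromo on an aromatic carbon. Going by the values given here, this is the same change as the one between compound 1 and compound 2, now made on the core of compound 3; the surroundings of the place are described in the same words for both pairs. Among the compounds with values here, the expected step of a 1.9-fold higher number from compound 3 to compound 4 (0.28 log units; within the scatter) is taken to match the earlier step of a 2.0-fold higher number from compound 1 to compound 2 (0.30 log units; within the scatter), which is the only time this change has been measured. On that basis compound 4 is expected to give about 22000 nM in this assay. The estimate for compound 4 is expected to lie between 9000 nM and 55000 nM. With a single earlier example, and that one within the usual scatter, this expectation rests on slim ground.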

Compound 4, half-maximal inhibitory concentration: 34900 nM
Estimate against measurement, compound 4: 1.6-fold (0.20 log units) below, within the range that was stated.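

Removing the bromo from the fluorinated core gives a 3.0-fold higher number from compound 3 to compound 4 (0.48 log units; beyond the scatter) in this assay, and this step agrees with the one seen for the same change on the core of compound 1: the same change on two cores in this assay, a 2.0-fold higher number (0.30 log units; within the scatter) from compound 1 to compound 2 and a 3.0-fold higher number (0.48 log units; beyond the scatter) from compound 3 to compound 4, 1.5-fold (0.18 log units) apart, within the scatter of two such steps. Adding the fluoro to the core that carries a plain phenyl gives a 2.2-fold higher number from compound 2 to compound 4 (0.35 log units; beyond the scatter), and this step likewise agrees with its earlier counterpart: the same change on two cores in this assay, a 1.5-fold higher number (0.17 log units; within the scatter) from compound 1 to compound 3 and a 2.2-fold higher number (0.35 log units; beyond the scatter) from compound 2 to compound 4, 1.5-fold (0.18 log units) apart, within the scatter of two such steps. Each change therefore carried over from one core to the other as far as can be told, but this is not a general rule: each has been seen only twice, both comparisons rest on the same four compounds, and although only the new steps pass beyond the scatter, the gaps between paired steps do not show that either change has a larger effect on the second core.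

The compounds shown leave open what other groups at the same place, on the ring that carries the bromo in compound 3, would do, such as chloro, methoxy or an amine. They also leave open whether a group other than fluoro on the core, such as chloro or methyl, would combine with the 4-bromophenyl to phenyl change in the same way.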